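The source may report more compounds than this note shows. Statements on the series, on what has been measured and on what is new or still open speak of the compounds shown alone.

Working notes on the series. Compound 2 `O=C(/C=C1\CCc2ccc(F)cc21)NC1CCCC1` stands at the bottom of the three numbers obtained so far: in a functional assay on the whole organism with Mus musculus as the target, at a dose of 100 mg/kg by the intraperitoneal route (on this read-out lower numbers stand for less inhibition and higher numbers for more inhibition at the one dose given (going by the name of the read-out)), compound 2 gives 0%. The other two measured members lie far above it. Compound 1 `Cc1cccc2c1CC/C2=C\C(=O)NC1CC1`, which carries a cyclopropyl on the amide nitrogen and a methyl on the core, in this assay gives 100%. Compound 3 `NC(=O)/C=C1\CCc2cc(F)cc(F)c21`, an amide with no substituent on its nitrogen and two fluorines on the core, in this assay gives 100%. Both gaps to compound 2 lie beyond the scatter, so the number of compound 2 is the lowest of the three. Going by the values given here, no two measured compounds differ in a single place, so no isolated step has been characterised yet.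

Compound 4 `CNC(=O)/C=C1\CCc2ccc(F)cc21` keeps the core of compound 2 and differs from it only at the amide nitrogen: methyl in place of cyclopentyl on an amide-type nitrogen. Cut one bond further out, the change reads cyclopentylamino to methylamino.

The two members with the smaller amide substituents, compound 1 at 100% and compound 3 at 100%, both show a higher inhibition in this assay than compound 2, though their cores also differ from that of compound 2, so the comparison is loose. On that basis a rise from compound 2 to compound 4 is expected, a number 70 percentage points higher from compound 2 to compound 4 (beyond the scatter), beyond the scatter. Compound 4 is estimated at 70%, within a range of 20% to 100%.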

Compound 4, a percentage reported as inhibition, in the whole organism at one dose (the size of the read-out at that dose, not a potency): 50%
The estimate for compound 4 lay 20 percentage points above the measured number; the measured number falls inside the stated range.
By their numbers in this assay, from the lowest: compound 2; then compound 4; then compounds 1 and 3 (each within the scatter of the next).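

In this assay, the exchange of cyclopentyl for methyl on an amide-type nitrogen, with the core held fixed, gives a number 50 percentage points higher from compound 2 to compound 4 (beyond the scatter), a large step and the first isolated one in the series. Going by these compounds alone, the read-out therefore responds to the substituent at this position alone, which the earlier compounds could not show, since their cores differ from that of compound 2 as well as their amide substituents. No measurement on these compounds bears on what lies behind the step, so it stands as an observation without an explanation.

On these data alone, with only two substituents compared on this core, it remains open whether the number moves gradually through a run of amide substituents or whether the step is specific to cyclopentyl, and ethyl, isopropyl or a longer chain such as butyl on the same nitrogen would help to separate these readings. As far as these compounds go, it is also open whether the same exchange gives a step of similar size on the core of compound 1 or the core of compound 3, where the substituents on the core differ.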